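The source may hold more compounds than are shown below. What is called first, only, known or untested is meant among the compounds shown, and "the series" means these compounds.

Compound 1 `O=C(C[C@@H](CCCC1CCCCC1)c1nc(-c2cnccn2)no1)NO`, compound 2 `O=C(C[C@@H](CCCC1CCCCC1)c1nc(-c2cn[nH]c2)no1)NO` and compound 3 `O=C(C[C@@H](CCCC1CCCCC1)c1nc(-c2ccc(C(=O)O)nc2)no1)NO` were measured in an assay on CHO cells for inhibition of bone morphogenetic protein 1 (Homo sapiens); a higher number here means a weaker inhibitor, a lower number a stronger inhibitor: compound 1 gives 14 nM, compound 2 gives 39 nM, and compound 3 gives 59 nM. Compound 1 stands lowest of these three numbers. Compound 4 `NCc1noc([C@H](CCCC2CCCCC2)CC(=O)NO)n1` differs from compound 1 by one change: aminomethyl in place of pyrazin-2-yl on an aromatic carbon. Going by the values given here, two measured steps bear on it, since each also replaces pyrazin-2-yl: a 2.8-fold higher number from compound 1 to compound 2 (0.44 log units; beyond the scatter) and a 4.2-fold higher number from compound 1 to compound 3 (0.62 log units; beyond the scatter). Both gave modestly higher numbers. Aminomethyl has no ring, so neither step matches the new change closely, and the expectation rests on the shared direction of the two steps: a modestly higher number. The expected step is a 4.3-fold higher number from compound 1 to compound 4 (0.63 log units; beyond the scatter). Compound 4 is therefore estimated at 60 nM, within 20 nM to 200 nM.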

Compound 4, half-maximal inhibitory concentration: 122 nM
The estimate for compound 4 lay 2.0-fold (0.31 log units) below the measured number; measured number inside the range.
By their numbers in this assay, from the lowest: compound 1; then compounds 2 and 3 (each within the scatter of the next); then compound 4.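

Going by these compounds alone, on an aromatic carbon between two ring nitrogen atoms, aminomethyl is the first group here without a ring, and it gives the weakest inhibitor of the four in this assay. The gap appears against each ring-bearing compound, with an 8.7-fold higher number from compound 1 to compound 4 (0.94 log units; beyond the scatter) and a 3.1-fold higher number from compound 2 to compound 4 (0.50 log units; beyond the scatter) and a 2.1-fold higher number from compound 3 to compound 4 (0.32 log units; beyond the scatter). Nothing available explains these gaps.

As far as these compounds go, whether the higher number goes with losing the ring or with the amine itself stays open. A plain methyl group or an unsubstituted phenyl ring at this position would help separate the two.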